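A Small Swap on the Aromatic Ring

A few compounds are considered here, and "the series" means these few. Any claim that something is new, unique, unknown or untested is made for them only; others in the source may bear on it.

Two close relatives have been tested in an ADME assay on TERT-RPE1 cells (Homo sapiens) for cytotoxicity, read by MTT assay, with a stated time of 72 h; a lower number here means a stronger inhibitor, a higher number a weaker inhibitor. Compound 1 `COc1ccc(/C=C2/CN(C)/C(=N/c3ccc(C)cc3)S2)cc1` gives 65700 nM in this assay. Compound 2 `COc1ccc(/C=C2\S/C(=N\c3ccc(C(C)(C)C)cc3)N(C)C2=O)cc1` gives 46700 nM in this assay. On these two numbers compound 2 stands beside compound 1: the two values lie within the scatter of repeated measurements of each other, so nothing separates them.

The next compound, compound 3 `COc1ccc(/C=C2\S/C(=N\c3ccc(F)cc3)N(C)C2=O)cc1`, differs from compound 2 in one place: fluoro in place of tert-butyl on an aromatic carbon. The change is small and keeps the rest of the structure, including the shared core, untouched. Among the compounds with values here, no measured pair in this set shows what such a swap does in this assay, so there is no step to lean on.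

With both measured compounds sitting in the same region and no guidance from a measured step, the expected step from compound 2 to compound 3 is a 1.2-fold higher number from compound 2 to compound 3 (0.07 log units; within the scatter), that is, no change beyond the scatter. Compound 3 is therefore estimated at 55000 nM, with a range from 20000 nM to 150000 nM.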

Compound 3, half-maximal inhibitory concentration: > 100000 nM
Compound 3: a limit, no number; the forecaster's own chance of this, stated with the estimate: 25%; middle value at least 1.8-fold (0.25 log units) from the limit.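

In this assay compound 3 gives > 100000 nM, which is a limit of the assay and not a number. Even so, this pair supplies the only measured step in the set: fluoro in place of tert-butyl on an aromatic carbon, para to a large group, gives an at least 2.1-fold higher number from compound 2 to compound 3 (0.33 log units; beyond the scatter), so the group at this one position does move the result, and the tert-butyl compound is the stronger inhibitor of the pair. The full size of the step cannot be read, and only its minimum is known: the limit of > 100000 nM in this assay, at which 1 of the 3 values shown sits.

A single pair cannot show whether the result tracks the size of the group at this position or some other difference between tert-butyl and fluoro. It also leaves open where other groups in the same place would fall, such as an amine, a carboxylic acid or a longer chain, and whether any of them would bring the number back toward that of compound 2 or take it lower still.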